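Isopropyl in place of methyl on the shared core

This account rests on a few compounds, and the source may have more. Where it says the series, first, only, none or still open, it means among the compounds named here.

In an ADME assay on Caco-2 cells (Homo sapiens) for permeability, in the apical to basolateral direction (a higher number here means that the compound crosses the layer faster, a lower number that the compound crosses the layer more slowly), compound 1 (`COC(=O)N1CCN([C@H]2CC[C@H](Nc3ncnn4ccc([C@H](C)CC(=O)N(C)C)c34)CC2)CC1`) gives 18 10^-6 cm/s and compound 3 (`CC(=O)N1CCN([C@H]2CC[C@H](Nc3ncnn4ccc(C5CCOCC5)c34)CC2)CC1`) gives 30 10^-6 cm/s. Compound 2 (`Cc1ccn2ncnc(N[C@H]3CC[C@H](N(C)C)CC3)c12`) gives 36 10^-6 cm/s, within the scatter of both other numbers. Compound 4 (`CC(C)c1ccn2ncnc(N[C@H]3CC[C@H](N(C)C)CC3)c12`) is unmeasured and differs from compound 2 by isopropyl in place of methyl on an aromatic carbon. Going by the values given here, no measured pair isolates this change, so direct evidence is lacking. Compound 3, which carries a larger group on that aromatic carbon and a different amine, gives 30 10^-6 cm/s, within the scatter of compound 2. In this assay the expected step of a 1.1-fold lower number from compound 2 to compound 4 (0.05 log units; within the scatter) therefore stays within the scatter. For compound 4 the estimated value is 32 10^-6 cm/s, with an expected range of 17 10^-6 cm/s to 55 10^-6 cm/s.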

Compound 4, apparent permeability: 26 10^-6 cm/s
Estimate against measurement, compound 4: 1.2-fold (0.09 log units) above; low and high end bracket the measured number.
By their numbers in this assay, from the lowest: compounds 1, 4, 3 and 2 (each within the scatter of the next).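

In this assay, going by these compounds alone, the pair of compound 2 and compound 4 isolates this change for the first time, giving a 1.4-fold lower number from compound 2 to compound 4 (0.14 log units; within the scatter). On this aromatic carbon of the shared core, isopropyl in place of methyl therefore cannot be told apart from methyl in this read-out. No measurement at hand bears on a cause for this step.

Open, as far as these compounds go, is whether a carboxylic acid or a longer chain on this aromatic carbon would also stay within the scatter of compound 2. Also open, from the compounds shown here alone, is whether the same change behaves alike alongside the other amines of compound 1 and compound 3.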